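Pyridinyl in place of methylphenyl on the carbonyl carbon

The source may report more compounds than this note shows. Statements on the series, on what has been measured and on what is new or still open speak of the compounds shown alone.

Compound 2 `Cc1cccc(C(=O)n2c(-c3cn(-c4ccccc4)nc3-c3ccc(F)cc3)nc3ccccc32)c1` and compound 1 `Cc1cncc(C(=O)n2c(-c3cn(-c4ccccc4)nc3-c3ccc(F)cc3)nc3ccccc32)c1` share a core and differ only in the group on the carbonyl carbon. In an ADME assay on HEK-293T cells (Homo sapiens) for cytotoxicity, read by MTT assay, with a stated time of 24 h (a higher number here means that more compound is tolerated, a lower number that less compound is tolerated), compound 1 gives 119000 nM, and compound 2 gives 148000 nM; the two values sit within the scatter of each other, as the step of a 1.2-fold higher number from compound 1 to compound 2 (0.09 log units; within the scatter) shows. Compound 3 `O=C(c1cccnc1)n1c(-c2cn(-c3ccccc3)nc2-c2ccc(F)cc2)nc2ccccc21` continues this series with the change (pyridin-3-yl in place of 3-methylphenyl on a carbonyl carbon). Going by the values given here, the only measured step that bears on it is the one from compound 1 to compound 2, which exchanged one six-membered aromatic ring for another at the same carbonyl carbon and stayed within the scatter. On that basis no step beyond the scatter is expected in this assay, and the estimated step is a 1.2-fold lower number from compound 2 to compound 3 (0.09 log units; within the scatter). Compound 3 is therefore expected to give about 120000 nM, with a range from 60000 nM to 240000 nM.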

Compound 3, half-maximal cytotoxic concentration: 216000 nM
Beside the measured number, compound 3's estimate is 1.8-fold (0.26 log units) below it; measured number inside the range.
By their numbers in this assay, from the lowest: compounds 1, 2 and 3 (each within the scatter of the next).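

In this assay, pyridin-3-yl on the carbonyl carbon differs from 3-methylphenyl in two ways at once, gaining a ring nitrogen and losing the methyl, yet the combined change stays within the scatter (a 1.5-fold higher number from compound 2 to compound 3 (0.16 log units; within the scatter)). Taking the methyl off the pyridine ring alone, with hydrogen in its place on the aromatic carbon, also stays within the scatter (a 1.8-fold higher number from compound 1 to compound 3 (0.26 log units; within the scatter)), so neither the ring nitrogen nor this methyl separates these compounds in the assay, and nothing available offers an explanation for the values. The compounds shown carry only six-membered aromatic rings at this position. On these data alone, whether an amine, a carboxylic acid or a longer alkyl chain on the carbonyl carbon would stay within the scatter of these values remains open.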